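This account rests on a few compounds, and the source may have more. Where it says the series, first, only, none or still open, it means among the compounds named here.

All values in a toxicity assay on HT-29 cells (Homo sapiens) for cytotoxicity (on this read-out lower numbers stand for higher toxicity in this test and higher numbers for lower toxicity in this test), are limits, not numbers:
- compound 1 `CN1C(=S)[C@@H](NC(=O)c2n[nH]c(Cc3ccccc3)n2)COc2ccccc21` gives > 50000 nM
- compound 2 `CCCCCn1nc(C(=O)N[C@H]2COc3ccccc3N(C)C2=S)nc1Cc1ccccc1` gives > 100000 nM
- compound 3 `CC(C)n1nc(C(=O)N[C@H]2COc3ccccc3N(C)C2=S)nc1Cc1ccccc1` gives > 100000 nM

Compound 3 has only the limit > 100000 nM to show, and no number. Compound 4 `CC(C)Cn1nc(C(=O)N[C@H]2COc3ccccc3N(C)C2=S)nc1Cc1ccccc1` carries isobutyl in place of isopropyl on an aromatic nitrogen and is otherwise the same. The nearest evidence is a step that the two limits leave unreadable from compound 2 to compound 3, along with a step that the two limits leave unreadable from compound 1 to compound 2 and a step that the two limits leave unreadable from compound 1 to compound 3, so none of these has a size to carry over. With compound 2 and compound 3 both at the limit of > 100000 nM in this assay, at which 2 of the 3 values shown sit, no step beyond the scatter is expected in this assay, and another limit is likely. The expected step is a number no higher from compound 3 to compound 4 (the limit leaves the size open), as estimated here. Compound 4 is estimated at 100000 nM, with an expected range from 50000 nM to 200000 nM.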

Compound 4, half-maximal cytotoxic concentration: > 100000 nM
Compound 4: no number, only a limit (the forecaster's own chance of this, stated with the estimate: 90%); the middle value lies on the limit itself.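

Among these compounds, compound 4, like compound 1, compound 2 and compound 3, gives only a limit, so no step among them can be read. The compounds shown leave open whether the group on the aromatic nitrogen changes the read-out at all in this assay.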